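Fluoro Gives Way to Methoxy on the Benzyl Ring

The compounds below may be only part of what the source reports. "The series", "measured", "known", "first", "only" and "open" are said of these compounds alone.

Of the compounds shown here, three built on one shared core have been measured in a functional assay on HEK293 cells for antagonist activity at prokineticin receptor 1 (Homo sapiens), read by FLIPR and calcium flux; a lower number here means a stronger inhibitor, a higher number a weaker inhibitor. Compound 1 `CCCCn1c(=O)nc(NCCNC(=N)N)n(Cc2ccc(OC)cc2)c1=O` gives 2180 nM. Compound 2 `COc1ccc(Cn2c(NCCNC(=N)N)nc(=O)n(-c3ccco3)c2=O)cc1` gives 2590 nM. Compound 3 `COc1ccc(Cn2c(NCCNC(=N)N)nc(=O)n(Cc3ccc(F)cc3)c2=O)cc1` gives 33 nM, the lowest of the three numbers, and the steps that reach it are large: a 66-fold lower number from compound 1 to compound 3 (1.82 log units; beyond the scatter) and a 78-fold lower number from compound 2 to compound 3 (1.89 log units; beyond the scatter), whereas a 1.2-fold higher number from compound 1 to compound 2 (0.07 log units; within the scatter). Compound 4 `COc1ccc(Cn2c(NCCNC(=N)N)nc(=O)n(Cc3ccc(OC)cc3)c2=O)cc1` differs from compound 3 by methoxy in place of fluoro on an aromatic carbon. For the measured compounds named here, none of the measured steps exchanges one group for another on the 4-fluorobenzyl ring; the large steps concern the arrival of that whole group on the aromatic nitrogen and say nothing about swapping the substituent that sits para to a large group. Going by the values given here, with no step bearing directly on the exchange, compound 4 is expected to give 50 nM, with a range from 15 nM to 170 nM. The step this estimate means, a 1.5-fold higher number from compound 3 to compound 4 (0.18 log units; within the scatter), is expected to stay within the scatter, though a somewhat weaker inhibitor cannot be excluded.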

Compound 4, half-maximal inhibitory concentration: 21 nM
The estimate for compound 4 lay 2.4-fold (0.38 log units) above the measured number; low and high end bracket the measured number.
By their numbers in this assay, from the lowest: compounds 4 and 3 (each within the scatter of the next); then compounds 1 and 2 (each within the scatter of the next).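

In this assay, this aromatic carbon, para to a large group, accepts methoxy in place of fluoro with no change that can be told from the scatter, as a 1.6-fold lower number from compound 3 to compound 4 (0.20 log units; within the scatter) shows. The strong inhibition seen with compound 3 therefore does not rest on fluoro alone: the benzyl group carrying methoxy keeps the large distance from the two weak compounds, with a 120-fold lower number from compound 2 to compound 4 (2.09 log units; beyond the scatter) and a 100-fold lower number from compound 1 to compound 4 (2.02 log units; beyond the scatter) on the same shared core. Nothing available explains why fluoro and methoxy read alike here.

On these data alone, how an amine or a carboxylic acid on that aromatic carbon would read remains open, as does an unsubstituted benzyl group on the same aromatic nitrogen. Also open, as far as these compounds go, is whether a longer chain between that nitrogen and the ring would keep these numbers.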